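The compounds below may be only part of what the source reports. "The series", "measured", "known", "first", "only" and "open" are said of these compounds alone.

Measured in a functional assay on HOP-92 cells (Homo sapiens) for cytotoxicity, read by sulforhodamine B assay, with a stated time of 48 h; on this read-out lower numbers stand for stronger inhibition of growth and higher numbers for weaker inhibition of growth:
- compound 1, `CC1=C(C(=O)Nc2ccc(F)c(Cl)c2)C(c2cccc(Cl)c2)NC(=S)N1`: 32400 nM
- compound 2, `CC1=C(C(=O)Nc2ccc(Cl)c(Cl)c2)C(c2cccc(Cl)c2)NC(=O)N1`: 45700 nM
- compound 3, `CC1=C(C(=O)Nc2ccc(F)c(Cl)c2)C(c2cccc(Oc3ccccc3)c2)NC(=O)N1`: 40700 nM

Compound 1 has the lowest of the three numbers in this assay, but its nearest neighbour, compound 3, is within the scatter, and so is the furthest, compound 2; the three values cannot be told apart. Going by the values given here, no single-change step between measured compounds is available, so no measured step size can be quoted.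

Compound 4, `COc1cccc(C2NC(=S)NC(C)=C2C(=O)Nc2ccc(F)c(Cl)c2)c1`, differs from compound 1 in one place: methoxy in place of chloro on an aromatic carbon. Among the compounds with values here, compound 3, which carries a phenoxy group in the same position as the chloro of compound 1, gives a number within the scatter of compound 1, which is the only guide to what a change at this position does here.

On that basis no step beyond the scatter is expected in this assay; the step of a 1.2-fold higher number from compound 1 to compound 4 (0.09 log units; within the scatter) is the expectation, close to none. Compound 4 is accordingly estimated at 40000 nM in this assay, with a range from 15000 nM to 100000 nM.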

Compound 4, concentration for 50% growth inhibition: 50100 nM
Compound 4: the middle estimate sits 1.3-fold (0.10 log units) below what was measured, within the range that was stated.
By their numbers in this assay, from the lowest: compounds 1, 3, 2 and 4 (each within the scatter of the next).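

In this assay, going by these compounds alone, the exchange of chloro for methoxy on the aromatic carbon gives a 1.5-fold higher number from compound 1 to compound 4 (0.19 log units; within the scatter), the first measured step at this position in which only one group differs. Within the data shown here, compound 3 could not show this, since it differs from compound 1 at this position and also in the sulfur-bearing part of the core, so the step from 3-chlorophenyl to 3-methoxyphenyl is the only clean reading here, and it cannot be told apart from no change. Nothing among the data shown accounts for the size of this step.

What the compounds shown leave open is whether any group at this position can move the number in this assay beyond the scatter, as none of them carries an amine, a carboxylic acid or a longer chain such as butoxy there. On these data alone, it also remains open whether methoxy in place of chloro would give a similar step on a core with a carbonyl in place of the sulfur-bearing group, or with another substitution on the anilide ring.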